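Replacing a Ring Hydrogen with a Thiophenylmethyl Group

This account rests on a few compounds, and the source may have more. Where it says the series, first, only, none or still open, it means among the compounds named here.

The pair comprises compound 1 `O=c1c(-c2ccccc2[N+](=O)[O-])nc2ccccc2n1Cc1ccccc1` and compound 2 `O=c1[nH]c2ccccc2nc1-c1cccc([N+](=O)[O-])c1`, both examined in an assay on cells for activation of Cystic fibrosis transmembrane conductance regulator (Homo sapiens), read by fluorescence, with a stated time of 10 min; on this read-out higher numbers stand for an effect only at larger amounts of compound and lower numbers for an effect already at smaller amounts. Compound 1 gives 1000 nM in this assay. Compound 2 reaches only a limit of the assay, > 10000 nM, and so no number is known for it. Compound 2 therefore stands at the weak end of what the data show, because of the limit of > 10000 nM in this assay, at which 1 of the 2 values shown sits. Compound 3 `O=c1c(-c2cccc([N+](=O)[O-])c2)nc2ccccc2n1Cc1cccs1` is not yet measured and differs from compound 2 in one place: (thiophen-2-yl)methyl in place of hydrogen on an aromatic nitrogen. Compound 1 also carries a substituent on an aromatic nitrogen and reaches a measurable value, so a gain in this assay is expected an at least 6.6-fold lower number from compound 2 to compound 3 (0.82 log units; beyond the scatter), a step that appears beyond the usual scatter, though its exact size cannot be fixed from a limit. Compound 3 is therefore estimated at 1500 nM in this assay, with a range from 400 nM to 8000 nM.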

Compound 3, half-maximal effective concentration: 10 nM
The estimate for compound 3 lay 150-fold (2.18 log units) above the measured number; measured number outside the range, below it.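

With (thiophen-2-yl)methyl in place of hydrogen on the aromatic nitrogen, this assay records an at least 1000-fold lower number from compound 2 to compound 3 (3.00 log units; beyond the scatter). Within the data shown here, this is the first step at this position that can be read with nothing else changing, and it shows that the nitrogen carrying the hydrogen can take a substituent with a large gain on this read-out. The step gives only a minimum size, because compound 2 has no number of its own: the limit of > 10000 nM in this assay, at which 1 of the 3 values shown sits.

From the compounds shown here alone, whether the gain belongs to the thiophene ring or to any group on this nitrogen stays open, and compound 1, which differs from compound 3 in more than one place, cannot settle it. A plain methyl, a longer alkyl chain or a chain ending in an amine at this nitrogen would separate these readings.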